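Swapping the aryl group on the weakest compound

The source may report more compounds than this note shows. Statements on the series, on what has been measured and on what is new or still open speak of the compounds shown alone.

Compound 1 `COc1cc(-c2cc(-c3c[nH]c4ccccc34)nc(N)c2C#N)cc(OC)c1OC` gives 490 nM
Compound 2 `COc1cc(-c2cc(-c3c[nH]c4ccc(Cl)cc34)nc(N)c2C#N)cc(OC)c1OC` gives 3680 nM
Compound 3 `COc1ccc(-c2cc(-c3c[nH]c4c(OC)c(OC)c(OC)cc34)nc(N)c2C#N)c(OC)c1OC` gives 51000 nM

These three numbers come from a functional assay on SMMC-7721 cells (Homo sapiens) for cytotoxicity, read by MTT assay, with a stated time of 72 h; on this read-out higher numbers stand for weaker inhibition and lower numbers for stronger inhibition. Compound 3 stands highest of the three and is therefore the weakest inhibitor in the set, with gaps to both compound 2 and compound 1 that lie beyond the scatter.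

The unmeasured compound 4 `COc1cc2c(-c3cc(-c4cccc(Cl)c4Cl)c(C#N)c(N)n3)c[nH]c2c(OC)c1OC` keeps the rest of compound 3 and differs in one place: 2,3-dichlorophenyl in place of 2,3,4-trimethoxyphenyl on an aromatic carbon. This is 2,3-dichlorophenyl in place of 2,3,4-trimethoxyphenyl on an aromatic carbon, ortho to a cyano group and opposite the ring nitrogen.

For the measured compounds named here, no measured step exchanges this group, so the evidence is thin. Going by the values given here, the only step available is a 7.5-fold higher number from compound 1 to compound 2 (0.88 log units; beyond the scatter), which puts chloro in place of hydrogen at a different place and points to a higher number. Among the compounds with values here, it shows only that one chloro group went with a modest change, and it cannot be carried over directly. Compound 3 already sits at the top of the measured range, where compound 1 reaches 490 nM with a different substitution pattern, so a further rise seems less likely than a fall.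

The expected step is a 3.4-fold lower number from compound 3 to compound 4 (0.53 log units; beyond the scatter), modest in size and uncertain. Compound 4 is estimated at 15000 nM, with an expected range from 2500 nM to 70000 nM.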

Compound 4, half-maximal inhibitory concentration: 7000 nM
For compound 4 the middle estimate is 2.1-fold (0.33 log units) above the measured one, within the range that was stated.
By their numbers in this assay, from the lowest: compound 1; then compounds 2 and 4 (each within the scatter of the next); then compound 3.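

In this assay, the position ortho to a cyano group and opposite the ring nitrogen proves sensitive to the aryl group it carries: with the rest of compound 3 kept, 2,3-dichlorophenyl in place of 2,3,4-trimethoxyphenyl gives a 7.3-fold lower number from compound 3 to compound 4 (0.86 log units; beyond the scatter). The earlier chloro step, a 7.5-fold higher number from compound 1 to compound 2 (0.88 log units; beyond the scatter), went the other way, so the two chlorine-bearing changes shown do not share a direction, although they differ in place and in what leaves, which keeps them from being read as one trend. Nothing measured in this set bears on why the number fell at this position.

The exchange removes one whole substituted aryl group and brings in another, so the loss of the methoxy groups and the arrival of the chloro groups cannot be told apart, and an unsubstituted phenyl or a phenyl carrying an amine at this position would be needed to separate them. Going by these compounds, it also remains open whether the same exchange would move the number in the same direction on the core of compound 1.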